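Chloro in Place of Hydrogen: Estimating Compound 3

A few compounds are considered here, and "the series" means these few. Any claim that something is new, unique, unknown or untested is made for them only; others in the source may bear on it.

Measured compounds:
Compound 1 `Cc1ccc(C2=NN(C(N)=S)CC2C)cc1`: 40%
Compound 2 `CC1CN(C(N)=S)N=C1c1ccccc1`: 40%

In an in vitro assay on cells for inhibition of Amine oxidase [flavin-containing] B (Homo sapiens), read by Amplex Red, with a stated time of 15 min, tested at 100 uM (a lower number here means less inhibition, a higher number more inhibition at the concentration tested (going by the name of the read-out)), compound 1 gives 40%. Compound 2 gives 40% in this assay. Among the measured compounds shown here, the single measured step, no change at the digits printed from compound 1 to compound 2 (within the scatter), is hydrogen in place of methyl on an aromatic carbon, and it leaves the read-out where it was. Compound 2 therefore stands level with compound 1 at the digits shown, and it is the nearest measured neighbour of the compound to come.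

The unmeasured compound 3 `CC1CN(C(N)=S)N=C1c1ccc(Cl)cc1` differs from compound 2 in one place: chloro in place of hydrogen on an aromatic carbon. For the measured compounds named here, the only step that bears on this change is the one from compound 1 to compound 2, which touched the same aromatic carbon and moved the read-out by nothing beyond the scatter. On that basis the chloro substitution is expected to give little change in this assay, with no clear direction, so the expected step is a number 2 percentage points higher from compound 2 to compound 3 (within the scatter). Compound 3 is therefore estimated at 42%, within a range of 25% to 60%.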

Compound 3, a percentage reported as inhibition, at one concentration (the size of the read-out at that concentration, not a potency): 40%
Compound 3: the middle estimate sits 2 percentage points above what was measured, within the range that was stated.
By their numbers in this assay, from the lowest: compounds 1, 2 and 3 (each within the scatter of the next).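

In this assay the chloro group, on an aromatic carbon of a six-membered aromatic ring of carbon only and para to a group of 9 heavy atoms, gives no change at the digits printed from compound 2 to compound 3 (within the scatter) when it replaces hydrogen. Set against methyl on that same carbon, chloro gives no change at the digits printed from compound 1 to compound 3 (within the scatter) and so adds a third group, and the first halogen, to the hydrogen and methyl already seen there, with all three read-outs within the scatter of one another. Nothing on hand accounts for this flat result.

The compounds shown leave open whether a quite different group on this carbon, such as an amine, a carboxylic acid or a longer alkyl chain, would move the read-out beyond the scatter, and whether any change elsewhere on the shared core would do so. Since each read-out is the size of the inhibition at a single concentration and not a potency, they also leave open whether these three compounds would separate in a full concentration series.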